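The source may hold more compounds than are shown below. What is called first, only, known or untested is meant among the compounds shown, and "the series" means these compounds.

Compound 1 `COc1ccc(/C=C2\CCC/C(=C\c3cccc(OC)c3OC)C2=O)cc1`: 401000 nM
Compound 2 `COc1ccc(/C=C2\CCC/C(=C\c3ccc([N+](=O)[O-])cc3)C2=O)cc1`: 435000 nM
Compound 3 `COc1cccc(/C=C2\CCC/C(=C\c3cc(OC)c(OC)c(OC)c3)C2=O)c1OC`: 29300 nM

All three compounds were tested in an ADME assay on Vero cells (Chlorocebus sabaeus) for inhibition; on this read-out higher numbers stand for lower toxicity in this test and lower numbers for higher toxicity in this test. Compound 3 gives the lowest number of the set, 29300 nM, which makes it the most toxic of the three in this test. Compound 1 and compound 2 both stand above it, beyond the scatter, and lie close to each other.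

Compound 4 `COc1ccc(/C=C2\CCC/C(=C\c3cccc(OC)c3OC)C2=O)cc1OC` has not yet been measured. The change that leads to it from compound 3 is hydrogen in place of methoxy on an aromatic carbon. Among the compounds with values here, no pair of measured compounds differs in one place only, so the data give no direct measure of such a change.

The expectation therefore rests on the values alone. Compound 4 carries fewer methoxy groups than compound 3, as does compound 1, which reaches 401000 nM. A rise in this assay beyond the scatter is therefore expected, though probably not the full distance to compound 1. The estimated step is a 4.1-fold higher number from compound 3 to compound 4 (0.61 log units; beyond the scatter). The expected value for compound 4 is 120000 nM, with an estimated range from 35000 nM to 420000 nM.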

Compound 4, half-maximal cytotoxic concentration: 36100 nM
The estimate for compound 4 lay 3.3-fold (0.52 log units) above the measured number; the measured number falls inside the stated range.
By their numbers in this assay, from the lowest: compounds 3 and 4 (each within the scatter of the next); then compounds 1 and 2 (each within the scatter of the next).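

In this assay, hydrogen in place of methoxy on an aromatic carbon, at the place ortho to a methoxy group and meta to a large group, gives a step that stays within the scatter (a 1.2-fold higher number from compound 3 to compound 4 (0.09 log units; within the scatter)), so at this position the presence of the methoxy group makes no readable difference to the number. The same kind of exchange at a different aromatic carbon behaves quite otherwise, since methoxy in place of hydrogen gives a large step beyond the scatter (an 11-fold lower number from compound 1 to compound 4 (1.05 log units; beyond the scatter)), which shows that the effect of a methoxy group in this series depends on the carbon that carries it and not simply on the count of such groups. Nothing at hand explains why the two places differ.

The compounds shown leave open whether this position would stay as undemanding with a hydroxyl group, a fluorine atom or an amine in place of the methoxy group. They also leave open whether the large step seen at the other aromatic carbon would recur with a second pair of compounds that differ only there.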